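From benzyl to 2,4-dichlorobenzyl on a shared core

A few compounds are considered here, and "the series" means these few. Any claim that something is new, unique, unknown or untested is made for them only; others in the source may bear on it.

In a functional assay on MDA-MB-231 cells (Homo sapiens) for cytotoxicity, read by MTT assay, with a stated time of 72 h (on this read-out lower numbers stand for stronger inhibition and higher numbers for weaker inhibition), compound 3 `CN(C)Cc1ccc2nc(NC(=O)N/N=C/c3cn(Cc4ccccc4)c4ccccc34)sc2c1` gives 1340 nM and sits within the scatter of compound 2 `CN(C)Cc1ccc2nc(NC(=O)N/N=C/c3c[nH]c4ccccc34)sc2c1` at 1190 nM while compound 1 `CCN(CC)Cc1ccc2nc(NC(=O)N/N=C/c3cn(Cc4ccc(Cl)cc4Cl)c4ccccc34)sc2c1` gives 3280 nM and so stands clearly higher than both.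

Compound 4 `CN(C)Cc1ccc2nc(NC(=O)N/N=C/c3cn(Cc4ccc(Cl)cc4Cl)c4ccccc34)sc2c1` differs from compound 3 in one place: 2,4-dichlorophenyl in place of phenyl on a saturated chain carbon bound to an aromatic nitrogen. In words, this is 2,4-dichlorophenyl in place of phenyl on a saturated chain carbon bound to an aromatic nitrogen.

Within the data shown here, only one measured step touches this place. Benzyl in place of hydrogen on an aromatic nitrogen gave a 1.1-fold higher number from compound 2 to compound 3 (0.05 log units; within the scatter) and says nothing about the chlorines. Among the measured compounds shown here, compound 1 already carries 2,4-dichlorophenyl but also differs from compound 4 elsewhere, so no measured pair isolates this change. Its number offers only a weak hint towards a higher value.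

No step beyond the scatter is therefore expected, only a slight upward lean, and the estimated step is a 1.3-fold higher number from compound 3 to compound 4 (0.13 log units; within the scatter) in this assay. For compound 4 the expected value is 1800 nM with an estimated range from 900 nM to 3500 nM in this test.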

Compound 4, half-maximal inhibitory concentration: 1410 nM
Beside the measured number, compound 4's estimate is 1.3-fold (0.11 log units) above it, within the range that was stated.
By their numbers in this assay, from the lowest: compounds 2, 3 and 4 (each within the scatter of the next); then compound 1.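

In this assay, adding the two chlorines does not move the number beyond the scatter (a 1.1-fold higher number from compound 3 to compound 4 (0.02 log units; within the scatter)), and neither does the whole 2,4-dichlorobenzyl group in place of hydrogen on the aromatic nitrogen (a 1.2-fold higher number from compound 2 to compound 4 (0.07 log units; within the scatter)). Among these compounds, compound 4 also shows what the earlier compounds could not separate: dimethylamino in place of diethylamino gives a modest step beyond the scatter (a 2.3-fold lower number from compound 1 to compound 4 (0.37 log units; beyond the scatter)), so the high number of compound 1 goes with its amine and not with its chlorines. Nothing available explains either result.

On these data alone, whether other groups on the benzyl ring, such as methoxy, or a longer chain such as phenethyl, would also stay within the scatter remains open. So does the effect of a cyclic amine such as morpholine in place of dimethylamino.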